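Methoxy to fluoro on a thiosemicarbazone aryl ring

A few compounds are considered here, and "the series" means these few. Any claim that something is new, unique, unknown or untested is made for them only; others in the source may bear on it.

Compound 1, `CC1=CC[C@H](C(C)(C)N=C=S)CC1`: > 100000 nM
Compound 2, `COc1ccc(/C=N/NC(=S)NC(C)(C)[C@H]2CC=C(C)CC2)cc1`: 8900 nM

In a functional assay on 786-0 cells (Homo sapiens) for inhibition, read by sulforhodamine B assay, with a stated time of 48 h (a lower number here means a stronger inhibitor of growth, a higher number a weaker inhibitor of growth), compound 2 gives 8900 nM, the only number shown. For compound 1 the value > 100000 nM is a limit of this assay, as noted in the limit of > 100000 nM in this assay, at which 1 of the 2 values shown sits. Compound 3, `CC1=CC[C@H](C(C)(C)NC(=S)N/N=C/c2ccc(F)cc2)CC1`, differs from compound 2 by fluoro in place of methoxy on an aromatic carbon. Going by the values given here, no measured pair covers this change, so the expected step of a 1.1-fold higher number from compound 2 to compound 3 (0.05 log units; within the scatter) is small, within the usual scatter, with no clear direction. Compound 3 is therefore estimated at 10000 nM, in the range 3000 nM to 35000 nM.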

Compound 3, concentration for 50% growth inhibition: > 100000 nM
Compound 3 was reported as a limit (the forecaster's own chance of this, stated with the estimate: 10%); middle value at least 10-fold (1.00 log units) away from the limit.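

Methoxy and fluoro are not interchangeable on this aromatic carbon of the shared core: the change brings an at least 11-fold higher number from compound 2 to compound 3 (1.05 log units; beyond the scatter) in this assay. The value of compound 3 is a limit, so the full size of this step cannot be read: the limit of > 100000 nM in this assay, at which 2 of the 3 values shown sit. Of these two groups at this place, only methoxy gives a number.

On these data alone, it remains open whether the oxygen or the methyl of the methoxy group matters here. As far as these compounds go, how a hydroxyl, a chlorine or an ethoxy group would read at this place also remains open.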